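The source may report more compounds than this note shows. Statements on the series, on what has been measured and on what is new or still open speak of the compounds shown alone.

Compound 1 `O=C(N1CCCCC1)N1CC(c2nc(-c3cccc(Cl)c3)no2)C1`: in an assay on HEK293 cells for positive allosteric modulation of metabotropic glutamate receptor 5 (Homo sapiens), read by FLIPR (a lower number here means that less compound is needed, a higher number that more compound is needed for the effect), compound 1 gives 370 nM.
Compound 2 `O=C(c1ccc(F)cc1)N1CC(c2nc(-c3cccc(Cl)c3)no2)C1`: in this assay compound 2 gives only a limit, > 10000 nM.
Compound 3 `O=C(C1CCC1)N1CC(c2nc(-c3cccc(Cl)c3)no2)C1`: in this assay compound 3 likewise gives only a limit, > 10000 nM.

Compound 3 thus stands at the limit of this assay, the limit at which two of the three values shown sit (the limit of > 10000 nM in this assay, at which 2 of the 3 values shown sit). Compound 4 `O=C(C1CCC2(CCC2)CC1)N1CC(c2nc(-c3cccc(Cl)c3)no2)C1` differs from compound 3 by a group of 9 heavy atoms (9 carbon; one four-membered non-aromatic ring of carbon only, one six-membered non-aromatic ring of carbon only) in place of a group of 4 heavy atoms (4 carbon; one four-membered non-aromatic ring of carbon only), on a carbonyl carbon. Among the measured compounds shown here, no measured step changes the carbonyl substituent in this way. For the measured compounds named here, the steps that bear on it all start from the piperidin-1-yl of compound 1: an at least 27-fold higher number from compound 1 to compound 3 (1.43 log units; beyond the scatter) and an at least 27-fold higher number from compound 1 to compound 2 (1.43 log units; beyond the scatter), both large losses that end at the limit; a step that the two limits leave unreadable from compound 2 to compound 3. The larger group of compound 4 therefore enters from a starting point where no number is read, and the measured steps give no case that a bigger saturated group recovers what the cyclobutyl lost. Compound 4 is expected to remain near the limit, with a step estimated as an at least 1.2-fold lower number from compound 3 to compound 4 (0.09 log units; that floor lies within the scatter). The estimate for compound 4 is 8000 nM, with an expected range from 1500 nM to 30000 nM.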

Compound 4, half-maximal effective concentration: 1100 nM
For compound 4 the middle estimate is 7.3-fold (0.86 log units) above the measured one, and the stated range ends above it.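

The group of 9 heavy atoms, all carbon, brings a readable number back to this carbonyl carbon in this assay, which neither the cyclobutyl nor the 4-fluorophenyl had given, the result being an at least 9.0-fold lower number from compound 3 to compound 4 (0.95 log units; beyond the scatter) and an at least 9.0-fold lower number from compound 2 to compound 4 (0.95 log units; beyond the scatter). A ring nitrogen on the carbonyl carbon is therefore not required for a readable number, although the piperidin-1-yl still holds the lower value, with a 3.0-fold higher number from compound 1 to compound 4 (0.47 log units; beyond the scatter). The two gains just named are only floors, and their true size stays unknown: the limit of > 10000 nM in this assay, at which 2 of the 4 values shown sit.

The compounds shown do not separate the count of carbons from the two-ring shape, since the cyclobutyl and the entering group differ in both, and a plain cyclohexyl on the same carbonyl carbon would speak to that question. Also open, on these data alone, is how a morpholine amide or an open chain such as n-hexyl would fare at this place, and whether the order seen here would hold on any core other than the shared one.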